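Exposure after an isoquinolinyl swap on the aryl ether

This account rests on a few compounds, and the source may have more. Where it says the series, first, only, none or still open, it means among the compounds named here.

Compound 1: `Cc1cn(-c2cc(NC(=O)c3ccc(C)c(Oc4ccccc4)c3)cc(C(F)(F)F)c2)cn1` — 541 ng.h/mL
Compound 2: `Cc1cn(-c2cc(NC(=O)c3ccc(C)c(Oc4ccccc4)c3)cc(N3CCN(C)CC3)c2)cn1` — 384 ng.h/mL

Two compounds have been run in an ADME assay on the whole organism (Mus musculus, strain CD1), read by LC-MS, using cassette dosing, with a stated time of 24 h, at a dose of 0.4 mg/kg by the intravenous route; on this read-out higher numbers stand for higher exposure at the dose given and lower numbers for lower exposure. Compound 1 gives 541 ng.h/mL, and compound 2 gives 384 ng.h/mL. Among the compounds with values here, the only measured step, a 1.4-fold lower number from compound 1 to compound 2 (0.15 log units; within the scatter), changes the group on the aromatic carbon of the shared core and leaves the two numbers within the scatter of each other, so compound 2 cannot be placed above or below compound 1 on these figures.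

Compound 3, `Cc1cn(-c2cc(NC(=O)c3ccc(C)c(Oc4cccc5ccncc45)c3)cc(N3CCN(C)CC3)c2)cn1`, differs from compound 2 at the aryl ether: isoquinolin-8-yl in place of phenyl on an oxygen on an aromatic ring. Within the data shown here, no measured step touches this oxygen-linked ring; the one step in hand, a 1.4-fold lower number from compound 1 to compound 2 (0.15 log units; within the scatter), sits elsewhere and was itself within the scatter. Nothing here therefore points to a large shift in either direction, and the expectation for compound 3 rests on compound 2 alone. Compound 3 is estimated at 350 ng.h/mL, with a range of 120 ng.h/mL to 1000 ng.h/mL, a step of a 1.1-fold lower number from compound 2 to compound 3 (0.04 log units; within the scatter) that is expected to stay near compound 2 but is held loosely for want of any comparable change.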

Compound 3, area under the concentration-time curve: 133 ng.h/mL
The estimate for compound 3 lay 2.6-fold (0.42 log units) above the measured number; low and high end bracket the measured number.
By their numbers in this assay, from the lowest: compound 3; then compounds 2 and 1 (each within the scatter of the next).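

In this assay, the oxygen-linked group proves to be a place where a single change moves the number: isoquinolin-8-yl in place of phenyl gives a 2.9-fold lower number from compound 2 to compound 3 (0.46 log units; beyond the scatter), whereas the earlier change on the aromatic carbon of the shared core, a 1.4-fold lower number from compound 1 to compound 2 (0.15 log units; within the scatter), did not move it beyond the scatter. The step is modest, but it shows that, with 4-methylpiperazin-1-yl held in place, exposure at the dose given is lower with the larger entering group, which brings one six-membered aromatic ring with 1 hetero atom and one hydrogen-bond acceptor. No measurement in hand explains why exposure falls with this change.

The compounds shown do not separate the ring nitrogen of isoquinolin-8-yl from the added ring itself, which an all-carbon naphthalen-1-yl or a single-ring pyridin-3-yl on the same oxygen could address. They also leave open whether the same swap would give a step of similar size with trifluoromethyl in place of 4-methylpiperazin-1-yl.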